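A methoxy group on a short-lived compound

The source may report more compounds than this note shows. Statements on the series, on what has been measured and on what is new or still open speak of the compounds shown alone.

In a physicochemical assay for pharmacokinetics, read by fluorescence and HPLC, with a stated time of 24 h (a lower number here means that the compound disappears faster, a higher number that the compound lasts longer), compound 1 `CC(C)(C)C1=C(C(=O)O)N2C(=O)CC2O1` gives 115 h and so lasts far longer than the two phenyl compounds. Compound 2 `CC(C)(C)C1=C(C(=O)O)N2C(=O)/C(=C/c3ccccc3)C2O1` gives 0.21 h and its double-bond isomer compound 3 `CC(C)(C)C1=C(C(=O)O)N2C(=O)/C(=C\c3ccccc3)C2O1` gives 0.17 h in the same test, which places compound 2 with compound 3 at the low end of the numbers. Compound 4 `COc1ccccc1/C=C1/C(=O)N2C(C(=O)O)=C(C(C)(C)C)OC12` differs from compound 2 by one change (methoxy in place of hydrogen on an aromatic carbon), with methoxy in place of hydrogen on an aromatic carbon. The only step among these close relatives, a 1.2-fold lower number from compound 2 to compound 3 (0.09 log units; within the scatter) in size, concerns the double bond and not a methoxy group, so no measured step predicts this change. The estimated 1.1-fold higher number from compound 2 to compound 4 (0.04 log units; within the scatter) is expected to stay within the scatter, without a firm direction. Compound 4 is expected at 0.23 h with a range from 0.08 h to 0.6 h in this assay when measured.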

Compound 4, half-life: 0.2 h
Compound 4: the middle estimate sits 1.2-fold (0.06 log units) above what was measured; the measured number falls inside the stated range.
By their numbers in this assay, from the lowest: compounds 3, 4 and 2 (each within the scatter of the next); then compound 1.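

In this assay, the change from phenyl to 2-methoxyphenyl gives a 1.1-fold lower number from compound 2 to compound 4 (0.02 log units; within the scatter), so a methoxy group on this aromatic carbon, ortho to a large group, leaves the number within the scatter. For the compounds shown here, until now the only step among the phenyl compounds concerned the double bond, and this is the first to touch the aromatic ring. Nothing available gives a reason for this result. The compounds shown leave open whether an amine or a carboxylic acid at this place would move the half-life beyond the scatter.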